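Carbamate side chain variation at the amide-bearing carbon

This account rests on a few compounds, and the source may have more. Where it says the series, first, only, none or still open, it means among the compounds named here.

Measured so far:
compound 1 `Cc1ncc([N+](=O)[O-])n1CCOC(=O)c1cc(NC(=O)[C@H](CCCCN)NC(=O)OCc2ccccc2)ccc1O` — 44.3%
compound 2 `Cc1ncc([N+](=O)[O-])n1CCOC(=O)c1cc(NC(=O)[C@@H](NC(=O)OCc2ccccc2)C(C)C)ccc1O` — 74.4%

In a functional assay on the whole organism (strain Wistar) for inhibition, with Rattus norvegicus as the target, read by paw edema, with a stated time of 1 h, at a dose of 10 mg/kg by the intraperitoneal route (a higher number here means more inhibition at the dose given (going by the name of the read-out), a lower number less inhibition), compound 2 stands highest of the two numbers; the nearest is compound 1, and the gap a number 30.1 percentage points higher from compound 1 to compound 2 (beyond the scatter) is large and beyond the scatter. Going by the values given here, this is the only measured step, and it sits on the same saturated chain carbon bound to an amide-type nitrogen and a carbonyl carbon that is now changed again.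

Compound 3 `Cc1ncc([N+](=O)[O-])n1CCOC(=O)c1cc(NC(=O)CNC(=O)OCc2ccccc2)ccc1O` is not yet measured. Its difference from compound 2: hydrogen in place of isopropyl on a saturated chain carbon bound to an amide-type nitrogen and a carbonyl carbon. The step of a number 30.1 percentage points higher from compound 1 to compound 2 (beyond the scatter) shows that this position moves the read-out substantially, but it involved two different carbon chains, so it fixes no direction for a hydrogen entering. The expectation is a downward step, a number 19.4 percentage points lower from compound 2 to compound 3 (beyond the scatter), of moderate size and with wide uncertainty. Compound 3 is therefore estimated at 55% in this assay, with a range from 30% to 78%.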

Compound 3, a percentage reported as inhibition, in the whole organism at one dose (the size of the read-out at that dose, not a potency): 56.1%
Beside the measured number, compound 3's estimate is 1.1 percentage points below it; the range from low to high includes it.
By their numbers in this assay, from the lowest: compound 1; then compound 3; then compound 2.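

With hydrogen as the reference at the saturated chain carbon bound to an amide-type nitrogen and a carbonyl carbon, the two chains move the read-out in opposite directions in this assay: isopropyl carries the higher number, shown by a number 18.3 percentage points lower from compound 2 to compound 3 (beyond the scatter), and 4-aminobutyl the lower, shown by a number 11.8 percentage points higher from compound 1 to compound 3 (beyond the scatter). The earlier large gap therefore resolves into two modest steps on either side of hydrogen, so across these three compounds the presence of a chain at this carbon does not by itself set the direction. No available data explain either step.

As far as these compounds go, it remains open whether the lower number of compound 1 goes with the amine or with the length of its chain, which a plain butyl chain would separate. A methyl group or a carboxylic acid at this carbon would show how far the range extends.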